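Methoxy on the benzyl amide of compound 3

A few compounds are considered here, and "the series" means these few. Any claim that something is new, unique, unknown or untested is made for them only; others in the source may bear on it.

compound 1 `COc1ccc(C[C@@H](O)/C=C/C=C/C(=O)NCc2ccc(Cl)cc2)cc1OC` gives 15700 nM 
compound 2 `COc1ccc(C[C@@H](O)/C=C/C=C/C(=O)N2CCCC2)cc1OC` gives 12000 nM 
compound 3 `COc1ccc(C[C@@H](O)/C=C/C=C/C(=O)NCc2ccccc2)cc1OC` gives 16600 nM 

All three values come from a functional assay on IMR-32 cells (Homo sapiens) for antiproliferative activity, read by sulforhodamine B assay, with a stated time of 48 h (a higher number here means a weaker inhibitor, a lower number a stronger inhibitor), and lie within the scatter of one another. Compound 3 shows a 1.4-fold higher number from compound 2 to compound 3 (0.14 log units; within the scatter) and so stands level with compound 2 on this read-out. Compound 4 `COc1ccc(CNC(=O)/C=C/C=C/[C@H](O)Cc2ccc(OC)c(OC)c2)cc1` carries one change from compound 3: methoxy in place of hydrogen on an aromatic carbon and this is methoxy in place of hydrogen on an aromatic carbon, para to a large group, so that benzyl becomes 4-methoxybenzyl.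

The most relevant measured step is the exchange of chloro for hydrogen on that ring, a 1.1-fold higher number from compound 1 to compound 3 (0.02 log units; within the scatter) and thus within the scatter. The amide exchange, a 1.3-fold lower number from compound 1 to compound 2 (0.12 log units; within the scatter) also within the scatter, shows the same flatness across compounds 1 to 3. For the measured compounds named here, no methoxy compound has been measured yet. The expected step is a 1.1-fold lower number from compound 3 to compound 4 (0.04 log units; within the scatter) and no shift beyond the scatter is expected in either direction in this assay on this evidence. For compound 4 the estimated value is 15000 nM with an expected range from 7500 nM to 30000 nM in this series.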

Compound 4, half-maximal inhibitory concentration: 17400 nM
For compound 4 the middle estimate is 1.2-fold (0.06 log units) below the measured one, within the range that was stated.
By their numbers in this assay, from the lowest: compounds 2, 1, 3 and 4 (each within the scatter of the next).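

In this assay, methoxy in place of hydrogen on the aromatic carbon para to a large group leaves the read-out within the scatter (a 1.0-fold higher number from compound 3 to compound 4 (0.02 log units; within the scatter)). Methoxy in place of chloro at the same place does the same (a 1.1-fold higher number from compound 1 to compound 4 (0.04 log units; within the scatter)), so with compound 4 this place has now carried hydrogen, chloro and methoxy with no step beyond the scatter among the three benzyl amides. Nothing at hand gives a measured reason for this flatness.

Going by these compounds, it remains open whether an amine, a carboxylic acid or a longer chain such as butoxy at this place would move the number beyond the scatter. Also open, on these data alone, is whether a change elsewhere on the shared core, such as an amine in place of the hydroxyl, would shift the read-out at all.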